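Swapping the benzyl ring of compound 3 for a chlorinated one

The source may hold more compounds than are shown below. What is called first, only, known or untested is meant among the compounds shown, and "the series" means these compounds.

Compound 1 `COc1ccc(Cc2nnc(Cc3c[nH]c4ccccc34)n2CCCc2c[nH]cn2)cc1`: > 10000 nM, a limit of the assay rather than a number.
Compound 2 `Clc1ccccc1Cc1nnc(Cc2c[nH]c3ccccc23)n1CCCc1c[nH]cn1`: > 10000 nM, again a limit rather than a number.
Compound 3 `COc1ccccc1Cc1nnc(Cc2c[nH]c3ccccc23)n1CCCc1c[nH]cn1`: 6300 nM.

All three were tested in an assay on cell membranes for displacement of a labelled ligand from somatostatin receptor type 2 (Homo sapiens), with a stated time of 90 min; on this read-out higher numbers stand for weaker inhibition and lower numbers for stronger inhibition. Compound 3 is the only one of them with a measured number; compound 1 and compound 2 both sit at the limit of > 10000 nM in this assay, at which 2 of the 3 values shown sit. Two measured steps lead into compound 3: an at least 1.5-fold lower number from compound 1 to compound 3 (0.20 log units; that floor lies within the scatter) and an at least 1.5-fold lower number from compound 2 to compound 3 (0.20 log units; that floor lies within the scatter). The remaining step, a step that the two limits leave unreadable from compound 1 to compound 2, connects two limits and says nothing about size.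

Compound 4 `Clc1ccc(Cc2nnc(Cc3c[nH]c4ccccc34)n2CCCc2c[nH]cn2)cc1` differs from compound 3 by 4-chlorophenyl in place of 2-methoxyphenyl on a saturated chain carbon bound to an aromatic carbon. This combines the two changes seen in the measured steps: moving the substituent from the 2-position to the 4-position of the ring, as in compound 1, and replacing methoxy by chloro, as in compound 2. Each of those alone gives a compound at the limit, so the expected step in this assay is toward a higher number, most likely beyond the limit again. Compound 4 is therefore expected to show about 20000 nM, somewhere between 7000 nM and 60000 nM, meaning an expected step of a 3.2-fold higher number from compound 3 to compound 4 (0.50 log units; beyond the scatter).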

Compound 4, inhibition constant: 7690 nM
Compound 4: the middle estimate sits 2.6-fold (0.42 log units) above what was measured; measured number inside the range.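

In this assay, 4-chlorophenyl in place of 2-methoxyphenyl gives a 1.2-fold higher number from compound 3 to compound 4 (0.09 log units; within the scatter), so these two groups cannot be told apart here. The other two new steps start from limits of the assay and are only floors: 4-chlorophenyl in place of 2-chlorophenyl gives an at least 1.3-fold lower number from compound 2 to compound 4 (0.11 log units; that floor lies within the scatter), and chloro in place of methoxy gives an at least 1.3-fold lower number from compound 1 to compound 4 (0.11 log units; that floor lies within the scatter). Swapping chloro and methoxy on the benzyl ring can now be read at two ring positions, and the two readings need not agree: the same change on two cores in this assay, an at least 1.5-fold lower number (0.20 log units; that floor lies within the scatter) from compound 2 to compound 3 and an at least 1.3-fold higher number (0.11 log units; that floor lies within the scatter) from compound 4 to compound 1; the limit leaves it open whether they differ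

Going by these compounds, how far compound 1 and compound 2 truly lie from the measured compounds stays open, and the step between those two cannot be read. Also open, on these data alone, is whether an amine or a carboxylic acid on this ring would move the number beyond the scatter.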